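Swapping the side group of compound 3 for a ring

The source may report more compounds than this note shows. Statements on the series, on what has been measured and on what is new or still open speak of the compounds shown alone.

Of the compounds shown here, three sharing one core have been measured in a functional assay with Oryctolagus cuniculus as the target (on this read-out higher numbers stand for weaker inhibition and lower numbers for stronger inhibition), and they differ in a single group on an aromatic carbon. Compound 1 `COc1ccc(-c2nc(/N=C(\N)N3CCOCC3)sc2-c2ccc(OC)cc2)cc1` gives < 1000 nM, which is a limit and not a number. Compound 2 `COc1ccc(-c2nc(CN(C)C)sc2-c2ccc(OC)cc2)cc1` gives 96 nM. Compound 3 `CCOC(=O)/C(C#N)=C/c1nc(-c2ccc(OC)cc2)c(-c2ccc(OC)cc2)s1` gives < 10 nM, which is also a limit.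

Within the data shown here, the one readable step that places compound 3 is an at least 9.6-fold lower number from compound 2 to compound 3 (0.98 log units; beyond the scatter). The other two steps are a step that the limit leaves unreadable from compound 1 to compound 2 and a step that the two limits leave unreadable from compound 1 to compound 3, so they offer no size to work with.

The next molecule is compound 4 `COc1ccc(-c2nc(C3=NNC(=O)CC3)sc2-c2ccc(OC)cc2)cc1`, and the change is a group of 7 heavy atoms (4 carbon, 2 nitrogen, 1 oxygen; one six-membered non-aromatic ring with 2 hetero atoms) in place of a group of 9 heavy atoms (6 carbon, 1 nitrogen, 2 oxygen; no ring), on an aromatic carbon. Among the measured compounds shown here, no measured step shows this exact swap. A higher number is the expected direction, since compound 2 at 96 nM shows that replacing the group at this place can cost clear ground. The expected change is an at least 3.0-fold higher number from compound 3 to compound 4 (0.47 log units; beyond the scatter). For compound 4 the estimated value in this assay is 30 nM, with an expected range from 5 nM to 200 nM.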

Compound 4, half-maximal inhibitory concentration: > 1000 nM
Compound 4 gave a limit, no number; the forecaster's own chance of this, stated with the estimate: 30%; at least 33-fold (1.52 log units) between middle value and limit.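

In this assay compound 4 gives > 1000 nM which is a limit and not a number. Even so, two steps can be read: there is an at least 100-fold higher number from compound 3 to compound 4 (2.00 log units; beyond the scatter) and there is an at least 10-fold higher number from compound 2 to compound 4 (1.01 log units; beyond the scatter) so at this aromatic carbon the new six-membered ring does clearly worse than both the 2-cyano-2-(ethoxycarbonyl)ethenyl group and the (dimethylamino)methyl group, and this place can cost far more ground than compound 2 alone showed. The third step is a number no lower from compound 1 to compound 4 (the limit leaves the size open) so the two ring-bearing groups cannot be ranked.

Going by these compounds, how far compound 4 lies past its limit stays open. So does how a carboxylic acid, a plain ethyl ester or a piperidine ring would read at this same place.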